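Cinnamamide Esters Against Inducible Nitric Oxide Synthase

A few compounds are considered here, and "the series" means these few. Any claim that something is new, unique, unknown or untested is made for them only; others in the source may bear on it.

Measured compounds:
compound 1 `CC[C@H](C)[C@H](NC(=O)/C=C/c1ccc(C(F)(F)F)cc1)C(=O)OC` 178 nM
compound 2 `CC[C@H](C)[C@H](NC(=O)/C=C/c1ccc(Cl)c(Cl)c1)C(=O)OC` 640 nM
compound 3 `COC(=O)[C@H](CC(C)C)NC(=O)/C=C/c1ccc(Cl)c(Cl)c1` 765 nM

In an assay on isolated protein for inhibition of Nitric oxide synthase, inducible (Homo sapiens), with a stated time of 1 h (a higher number here means a weaker inhibitor, a lower number a stronger inhibitor), compound 1 gives the lowest of the three numbers; compound 2 stands beyond the scatter from it, and compound 3 further still. The difference between the core of compound 1 and the core of compound 2 is not broken down here. Compound 3 differs from compound 2 by isobutyl in place of sec-butyl on a saturated chain carbon bound to an amide-type nitrogen and a carbonyl carbon, which gave a 1.2-fold higher number from compound 2 to compound 3 (0.08 log units; within the scatter).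

Compound 4 `COC(=O)[C@H](CC(C)C)NC(=O)/C=C/c1ccc(C(F)(F)F)cc1` is not yet measured. It differs from compound 1 by the same kind of change, (isobutyl in place of sec-butyl on a saturated chain carbon bound to an amide-type nitrogen and a carbonyl carbon). Because a 1.2-fold higher number from compound 2 to compound 3 (0.08 log units; within the scatter) stayed within the scatter, compound 4 is expected to give 210 nM, roughly 100 nM to 450 nM, so the estimated step is a 1.2-fold higher number from compound 1 to compound 4 (0.07 log units; within the scatter).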

Compound 4, half-maximal inhibitory concentration: 195 nM
For compound 4 the middle estimate is 1.1-fold (0.03 log units) above the measured one; the range from low to high includes it.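

In this assay the step of a 1.1-fold higher number from compound 1 to compound 4 (0.04 log units; within the scatter) comes with isobutyl in place of sec-butyl, so the change leaves the number unmoved on this core as well. The two cores shown give the same result for this change: the same change on two cores in this assay, a 1.2-fold higher number (0.08 log units; within the scatter) from compound 2 to compound 3 and a 1.1-fold higher number (0.04 log units; within the scatter) from compound 1 to compound 4, 1.1-fold (0.04 log units) apart, within the scatter of two such steps. This supports carrying the change between these two cores only; it does not show that the result holds on any other core, and it separates neither chain from the other on either core.

Open, on these data alone, is whether a longer chain, or a chain ending in an amine, would also leave the number unmoved at this place. Also open, as far as these compounds go, is whether a carboxylic acid in place of the ester would alter the result.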